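The source may hold more compounds than are shown below. What is called first, only, known or untested is meant among the compounds shown, and "the series" means these compounds.

Working notes on the series, read in an ADME assay on Huh-7 cells (Homo sapiens) for cytotoxicity, read by thymidine incorporation; on this read-out lower numbers stand for higher toxicity in this test and higher numbers for lower toxicity in this test. Compound 1 (`[N-]=[N+]=N[C@H]1C[C@H](n2cc(Br)c(=O)[nH]c2=O)O[C@@H]1CO`) gives > 100 ug/mL, which is a limit and not a number. Compound 2 (`Cc1cn([C@H]2C[C@H](N)[C@@H](CO)O2)c(=O)[nH]c1=O`) gives > 100 ug/mL, again a limit. Compound 3 (`CCc1cn([C@H]2C[C@H](I)[C@@H](CO)O2)c(=O)[nH]c1=O`) gives > 100 ug/mL, also a limit. Compound 3 therefore stands level with the other two compounds as far as can be told, and the series offers only (the limit of > 100 ug/mL in this assay, at which 3 of the 3 values shown sit). Among the measured compounds shown here, no pair of measured compounds differs in one place, so the series gives no size of step to draw on.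

Compound 4 (`CCc1cn([C@H]2C[C@H](F)[C@@H](CO)O2)c(=O)[nH]c1=O`) carries fluoro in place of iodo on a saturated ring carbon, next to the ring atom that bears a hydroxymethyl group: fluoro in place of iodo on a saturated ring carbon. For the measured compounds named here, no other fluoro compound has been measured, so the expectation rests only on (the limit of > 100 ug/mL in this assay, at which 3 of the 3 values shown sit). In this assay, no change beyond the usual scatter is expected, and no direction can be favoured with confidence. The expected change is a number no higher from compound 3 to compound 4 (the limit leaves the size open), an estimate that carries wide uncertainty. A reported limit is again the likelier outcome, although a measurable number cannot be ruled out. Compound 4 is estimated at 100 ug/mL, with an expected range of 30 ug/mL to 200 ug/mL.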

Compound 4, half-maximal cytotoxic concentration: > 100 ug/mL
Compound 4: a limit, no number; the forecaster's own chance of this, stated with the estimate: 65%; the middle value sits exactly at the limit.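

The step between compound 3 and compound 4, fluoro in place of iodo on a saturated ring carbon, cannot be read: both compounds are reported only as limits in this assay. The compounds shown leave open where any of their half-maximal cytotoxic concentrations lies and whether any structural change shifts it, as the series offers only one reference point: the limit of > 100 ug/mL in this assay, at which 4 of the 4 values shown sit.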